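Trading 3-methoxypropyl for 4-fluorobenzyl

A few compounds are considered here, and "the series" means these few. Any claim that something is new, unique, unknown or untested is made for them only; others in the source may bear on it.

Compound 1 `COCCOc1ccc(C(O)C2OC(=O)c3c(OC)cc(OC)cc32)cc1`: > 10000 nM (a limit)
Compound 2 `COCCCOc1ccc(C(O)C2OC(=O)c3c(OC)cc(OC)cc32)cc1`: 1260 nM

Both compounds were tested in a functional assay on RAW264.7 cells (Mus musculus) for inhibition, read by Griess assay, with stated times of 1 h and 24 h; on this read-out lower numbers stand for stronger inhibition and higher numbers for weaker inhibition. Compound 1 gives > 10000 nM, which is a limit of the assay and not a number. Going by the values given here, compound 2 gives 1260 nM, the only true number so far, so it serves as the reference point for what follows.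

Compound 3 `COc1cc(OC)c2c(c1)C(C(O)c1ccc(OCc3ccc(F)cc3)cc1)OC2=O` keeps the shared core and alters only the chain: 4-fluorophenyl in place of 2-methoxyethyl on a saturated chain carbon bound to an oxygen on an aromatic ring. In words, 4-fluorophenyl stands in place of 2-methoxyethyl on a saturated chain carbon bound to an oxygen on an aromatic ring. Cut one bond further out, this reads 3-methoxypropyl to 4-fluorobenzyl.

Among the compounds with values here, only one measured step bears on this: an at least 7.9-fold lower number from compound 1 to compound 2 (0.89 log units; beyond the scatter). It shows that a change in this chain can shift the value, but it is a single step and brings in no ring, so it gives only a weak guide to direction. A small move towards a lower number is the best guess. The expected change is a 1.4-fold lower number from compound 2 to compound 3 (0.15 log units; within the scatter), an estimate that points to no clear step beyond the scatter. Compound 3 is expected at 900 nM, with an estimated range of 200 nM to 4500 nM.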

Compound 3, half-maximal inhibitory concentration: 760 nM
The estimate for compound 3 lay 1.2-fold (0.07 log units) above the measured number; measured number inside the range.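

In this assay, 4-fluorobenzyl in place of 3-methoxypropyl gives a 1.7-fold lower number from compound 2 to compound 3 (0.22 log units; within the scatter), so on this read-out the two chains cannot be told apart. This position therefore takes a six-membered aromatic ring of carbon only, with no hydrogen-bond acceptor in the group that enters, and the value stays within the usual scatter, at least for this one pair. The other new step, an at least 13-fold lower number from compound 1 to compound 3 (1.11 log units; beyond the scatter), gives only a minimum size, as it starts from a limit of the assay and not from a number: the limit of > 10000 nM in this assay, at which 1 of the 3 values shown sits.

The compounds shown leave open what the fluorine contributes, which a plain benzyl group would test, and whether a longer chain such as 4-methoxybutyl would give a lower number still. They also leave open whether an amine or a carboxylic acid at the end of the chain would be tolerated at this position, and everything here rests on a single read-out in cells.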